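A few compounds are considered here, and "the series" means these few. Any claim that something is new, unique, unknown or untested is made for them only; others in the source may bear on it.

Measured compounds in a functional assay on RPMI-8226 cells (Homo sapiens) for inhibition, read by sulforhodamine B assay, with a stated time of 48 h, tested at 1 uM; on this read-out lower numbers stand for a stronger effect and higher numbers for a weaker effect at the one concentration tested:

compound 1, `O=C(Nc1cccc(-n2cc(-c3ccncc3)c(-c3cc(O)cc(Cl)c3)n2)c1)Nc1ccc(Cl)c(C(F)(F)F)c1`, gives 88%
compound 2, `O=C(Nc1cccc(-n2cc(-c3ccncc3)c(-c3cc(O)cc(Cl)c3)n2)c1)Nc1ccc(Cl)c(Cl)c1`, gives 57%
compound 3, `COc1cc(Cl)cc(-c2nn(-c3cccc(NC(=O)Nc4ccc(Cl)c(C(F)(F)F)c4)c3)cc2-c2ccncc2)c1`, gives 17%

Compound 3 stands lowest of the three numbers, with compound 2 nearest and compound 1 furthest, both of them beyond the scatter. The two measured steps set the frame: a number 31 percentage points lower from compound 1 to compound 2 (beyond the scatter), and a number 71 percentage points lower from compound 1 to compound 3 (beyond the scatter).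

Compound 4, `COc1cc(Cl)cc(-c2nn(-c3cccc(NC(=O)Nc4ccc(Cl)c(Cl)c4)c3)cc2-c2ccncc2)c1`, has not yet been measured in this assay. It differs from compound 3 in one place: chloro in place of trifluoromethyl on an aromatic carbon. Among the measured compounds shown here, this is the same change as the one from compound 1 to compound 2, where the number fell by a large amount. If the change acts the same way on the shared core of compound 3, the number for compound 4 should move down again, though compound 3 already sits low, so the step can hardly be as large. The step from compound 3 to compound 4 is therefore expected to be a number 7 percentage points lower from compound 3 to compound 4 (within the scatter), a modest fall. Compound 4 is estimated to give 10%, within the range 0% to 30%.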

Compound 4, a percentage reported as activity, at one concentration (the size of the read-out at that concentration, not a potency): 39%
Beside the measured number, compound 4's estimate is 29 percentage points below it; measured number outside the range, above it.
By their numbers in this assay, from the lowest: compound 3; then compound 4; then compound 2; then compound 1.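

On the core with methyl on the oxygen, chloro in place of trifluoromethyl gives a number 22 percentage points higher from compound 3 to compound 4 (beyond the scatter) in this assay, the opposite direction to the same change on the core of compound 1: the same change on two cores in this assay, a number 31 percentage points lower (beyond the scatter) from compound 1 to compound 2 and a number 22 percentage points higher (beyond the scatter) from compound 3 to compound 4, 53 percentage points apart, beyond the scatter of two such steps. With chloro at this position, methyl on the oxygen still gives a number 18 percentage points lower from compound 2 to compound 4 (beyond the scatter), a much smaller fall than with trifluoromethyl: the same change on two cores in this assay, a number 71 percentage points lower (beyond the scatter) from compound 1 to compound 3 and a number 18 percentage points lower (beyond the scatter) from compound 2 to compound 4, 53 percentage points apart, beyond the scatter of two such steps. The effect of each change therefore depends on the other, so neither can be carried over from one core to the other as a fixed step.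

These four compounds cannot say why the direction reverses. They also leave open how a bromo or nitrile group would behave at this position, and whether an ethyl group on the oxygen would act like methyl.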